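This account rests on a few compounds, and the source may have more. Where it says the series, first, only, none or still open, it means among the compounds named here.

Of the compounds shown here, two of a shared core have been tested in a functional assay on the whole organism (strain Wistar albino) for inhibition, with Rattus norvegicus as the target, read by paw edema, at a dose of 10 mg/kg by the oral route; a higher number here means more inhibition at the dose given (going by the name of the read-out), a lower number less inhibition. Compound 1 `Cc1ccccc1OCc1ccccc1-c1nc(CN2CCN(C(c3ccccc3)c3ccc(Cl)cc3)CC2)cs1` gives 63.2% in this assay . Compound 2 `Cc1ccccc1OCc1ccccc1-c1nc(COc2ccc(Cl)cc2)cs1` gives 65.1% in this assay , and the two numbers sit within the scatter of each other, so neither compound can be set apart from the other on these data. Among the measured compounds shown here, no step between them has been worked out, and only the pair of values is known.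

Compound 3 `Clc1ccc(OCc2csc(-c3ccccc3COc3ccc(Cl)cc3)n2)cc1` is the next compound to be measured in this assay , and it differs from compound 2 in one place: 4-chlorophenyl in place of 2-methylphenyl on an oxygen on a saturated carbon. For the measured compounds named here, nothing measured so far shows what this exchange does to the read-out, so the expectation for compound 3 rests on the level already seen for compound 2 in this assay , which is 65.1%. For compound 3 the expected step of a number 1.1 percentage points lower from compound 2 to compound 3 (within the scatter) is no change beyond the scatter. Compound 3 is therefore estimated at 64%, with a range from 50% to 78%.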

Compound 3, a percentage reported as inhibition, in the whole organism at one dose (the size of the read-out at that dose, not a potency): 76.4%
Beside the measured number, compound 3's estimate is 12.4 percentage points below it; low and high end bracket the measured number.
By their numbers in this assay, from the lowest: compounds 1 and 2 (each within the scatter of the next); then compound 3.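

Exchanging 2-methylphenyl for 4-chlorophenyl on an oxygen on a saturated carbon gives, in this assay, a number 11.3 percentage points higher from compound 2 to compound 3 (beyond the scatter). Among the compounds shown here, this is the first step that can be read as beyond the scatter, and it shows that the read-out responds to the group held at this position. The step is modest and rests on a single pair of compounds, and nothing available explains why the read-out moves with this exchange.

The exchange removes a methyl group and brings in a chlorine at a different ring position, so the compounds shown cannot tell which of these two differences matters. Going by these compounds, a plain phenyl, 4-methylphenyl or 2-chlorophenyl group at the same place would pull the two apart, and how any of them would read remains open.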